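Substituent on the ring nitrogen of the shared core

A few compounds are considered here, and "the series" means these few. Any claim that something is new, unique, unknown or untested is made for them only; others in the source may bear on it.

Measured compounds in a functional assay on U2OS cells with metabotropic glutamate receptor 5 (Homo sapiens) as the target, read by calcium flux; a higher number here means a larger maximal response, a lower number a smaller maximal response:
compound 1 `Fc1ccc(-c2noc(C3CCc4c(nnn4C4CCCC4)C3)n2)cc1` — 78%; 103% (2 entries)
compound 2 `CC(C)n1nnc2c1CCC(c1nc(-c3ccc(F)cc3)no1)C2` — 98%
compound 3 `CC1(n2nnc3c2CCC(c2nc(-c4ccc(F)cc4)no2)C3)CCOCC1` — 103%

All three share one core and a 4-fluorophenyl-bearing oxadiazole; they differ only in the group on the aromatic nitrogen. Compound 1 has two entries, (the several entries of compound 1 in this assay, 78%; 103% (2 entries)), which spread across the scatter and give no single number. Of the two single numbers, compound 3 and compound 2 are not told apart: a number 5 percentage points higher from compound 2 to compound 3 (within the scatter). Compound 3 therefore stands among the high responses without being separated from compound 2.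

Compound 4 `CC(C)(C)Cn1nnc2c1CCC(c1nc(-c3ccc(F)cc3)no1)C2` carries a further change at the same place: neopentyl in place of 4-methyloxan-4-yl on an aromatic nitrogen. Among the compounds with values here, the only measured step that bears on it is a number 5 percentage points higher from compound 2 to compound 3 (within the scatter), a swap of the group on the same aromatic nitrogen that left the maximal response unchanged within the scatter. Within the data shown here, no step at this position has moved the response beyond the scatter, so none is expected here either.

For compound 4 a maximal response of 99% is expected, within 82% to 114%. The step of a number 4 percentage points lower from compound 3 to compound 4 (within the scatter) is expected to stay within the scatter.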

Compound 4, largest response reached (reported as percent of maximum), in percent of the reference or control that the assay uses: 108%
Compound 4: middle estimate off by 9 percentage points, on the low side, and the stated range covers the measured number.
By their numbers in this assay, from the lowest: compounds 2, 3 and 4 (each within the scatter of the next).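

In this assay, neopentyl in place of 4-methyloxan-4-yl removes the six-membered non-aromatic ring and its hydrogen-bond acceptor, yet this change gives a number 5 percentage points higher from compound 3 to compound 4 (within the scatter) and so does not separate the two compounds. Neopentyl in place of isopropyl, two groups without a ring, gives a number 10 percentage points higher from compound 2 to compound 4 (within the scatter), so compound 2, compound 3 and compound 4 are not told apart, whether the group on this aromatic nitrogen is an all-carbon chain or an oxygen-bearing ring. Nothing measured here accounts for this lack of separation.

As far as these compounds go, whether a carboxylic acid or an amine on this aromatic nitrogen would move the maximal response beyond the scatter remains open. Also open is whether a phenyl ring in the same place would leave the response within the scatter of these compounds.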